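A Longer Chain at the Edge of the Toxicity Limit

The source may hold more compounds than are shown below. What is called first, only, known or untested is meant among the compounds shown, and "the series" means these compounds.

Compound 1 `O=C(N[C@H](/C=C/S(=O)(=O)c1ccccc1)CCc1ccccc1)c1cccc2cccnc12` gives > 80000 nM in an ADME assay on HepG2 cells (Homo sapiens) for cytotoxicity (on this read-out higher numbers stand for lower toxicity in this test and lower numbers for higher toxicity in this test), which is a limit of the test rather than a number.
Compound 2 `CC(C)C[C@@H](/C=C/S(=O)(=O)c1ccccc1)NC(=O)c1cccc2cccnc12` gives 15100 nM in this assay.
Compound 3 `CCC[C@@H](/C=C/S(=O)(=O)c1ccccc1)NC(=O)c1cccc2cccnc12` gives > 80000 nM in this assay, again a limit rather than a number.

Compound 3 thus stands at the limit of this assay, and among the values shown only compound 2 gives a real number. Compound 4 `CCCC[C@@H](/C=C/S(=O)(=O)c1ccccc1)NC(=O)c1cccc2cccnc12` differs from compound 3 by methyl in place of hydrogen on a saturated chain carbon, four bonds along the chain from an amide-type nitrogen and a double-bonded chain carbon. The step that bears most directly on this is an at least 5.2-fold higher number from compound 2 to compound 3 (0.72 log units; beyond the scatter), which runs the other way: taking a methyl away raised the number, so adding one might lower it. The step of an at least 5.2-fold lower number from compound 1 to compound 2 (0.72 log units; beyond the scatter) also lowered the number, and a step that the two limits leave unreadable from compound 1 to compound 3 cannot be read. Reading is hampered because of the limit of > 80000 nM in this assay, at which 2 of the 3 values shown sit. Among the compounds with values here, with two of three neighbours at the limit and compound 2 the only number, a modest decrease or no readable change is expected, an at least 1.7-fold lower number from compound 3 to compound 4 (0.24 log units; that floor lies within the scatter). Compound 4 is therefore estimated at 45000 nM in this assay, within 15000 nM to 90000 nM.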

Compound 4, half-maximal cytotoxic concentration: 36500 nM
Compound 4: middle estimate off by 1.2-fold (0.09 log units), on the high side, within the range that was stated.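

Compound 4 gives a real number in this assay, so this straight chain now has a measured point where compound 3 offers only a limit. Adding one methyl, four bonds along the chain from the amide-type nitrogen, gives an at least 2.1-fold lower number from compound 3 to compound 4 (0.34 log units; beyond the scatter), and ethyl in place of phenyl gives an at least 2.1-fold lower number from compound 1 to compound 4 (0.34 log units; beyond the scatter), so lengthening the chain from propyl to butyl can lower the number without any branch. Within the data shown here, the step with real numbers at both ends is a 2.4-fold higher number from compound 2 to compound 4 (0.38 log units; beyond the scatter), which gives this position its only fully sized comparison between a branched and an unbranched chain.

From the compounds shown here alone, the full size of the two steps that start from a limit stays unknown: the limit of > 80000 nM in this assay, at which 2 of the 4 values shown sit. Going by these compounds, whether a longer chain such as pentyl, or an amine at the end of the chain, would lower the number further remains open.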